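Nitrophenyl sulfonamide variant of a proline-derived compound measured by paw edema

This account rests on a few compounds, and the source may have more. Where it says the series, first, only, none or still open, it means among the compounds named here.

Of the compounds shown here, three have been tested in a functional assay on the whole organism for inhibition, with Rattus norvegicus as the target, read by paw edema, with stated times of 1 h and 0.5 h, at a dose of 100 mg/kg by the oral route; on this read-out lower numbers stand for less inhibition and higher numbers for more inhibition at the one dose given (going by the name of the read-out). Compound 1 `Cc1ccccc1S(=O)(=O)N1CC(O)C[C@H]1C(=O)Nc1ccc(C(=O)O)cc1` gives 38.6%, compound 2 `Cc1ccc(S(=O)(=O)N2CC(O)C[C@H]2C(=O)Nc2ccc(C(=O)O)cc2)cc1` gives 58%, and compound 3 `Cc1ccccc1S(=O)(=O)N1CCC[C@H]1C(=O)Nc1ccc(C(=O)O)cc1` gives 35.8%. Compound 3 holds the lowest of the three numbers; its nearest neighbour is compound 1, a difference that lies within the scatter, while compound 2 stands furthest from it, beyond the scatter. Between compound 1 and compound 2 the change is 4-methylphenyl in place of 2-methylphenyl on a sulfonyl sulfur, and it brought a number 19.4 percentage points higher from compound 1 to compound 2 (beyond the scatter). Between compound 1 and compound 3 the change is hydrogen in place of hydroxy on a saturated ring carbon, with a number 2.8 percentage points lower from compound 1 to compound 3 (within the scatter).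

Compound 4 `O=C(O)c1ccc(NC(=O)[C@@H]2CCCN2S(=O)(=O)c2ccc([N+](=O)[O-])cc2)cc1` awaits measurement in this assay. It differs from compound 3 in one place: 4-nitrophenyl in place of 2-methylphenyl on a sulfonyl sulfur. Among the measured compounds shown here, the only measured step that bears on it is the one from compound 1 to compound 2, which also exchanged the 2-methylphenyl on the sulfonyl sulfur for a group bearing its substituent at the 4-position. For the measured compounds named here, no measured compound carries a nitro group, so the size of that part of the change is unknown. On the basis of the step from compound 1 to compound 2, compound 4 is expected to show a rise of a number 14.2 percentage points higher from compound 3 to compound 4 (beyond the scatter), modest and beyond the scatter. The estimate for compound 4 in this assay is 50%, with a range from 32% to 68%.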

Compound 4, a percentage reported as inhibition, in the whole organism at one dose (the size of the read-out at that dose, not a potency): 42.1%
Compound 4: the middle estimate sits 7.9 percentage points above what was measured, and the stated range covers the measured number.
By their numbers in this assay, from the lowest: compounds 3, 1 and 4 (each within the scatter of the next); then compound 2.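

In this assay, 4-nitrophenyl in place of 2-methylphenyl on a sulfonyl sulfur, on the core without the hydroxy, gives a number 6.3 percentage points higher from compound 3 to compound 4 (within the scatter). Among the compounds shown here, this is the first sign that an exchange at this place need not carry the read-out beyond the scatter, since the earlier exchange of 2-methylphenyl for 4-methylphenyl, made on the core with the hydroxy, gave a number 19.4 percentage points higher from compound 1 to compound 2 (beyond the scatter). The two steps differ both in the entering group and in the core that carries it, so the compounds shown cannot say which of these separates them, and no measurement shown accounts for the result.

On these data alone, it remains open whether 4-methylphenyl would repeat its step on the core of compound 3, and whether 4-nitrophenyl would behave differently on the core of compound 1, where the hydroxy stands on the saturated ring carbon. Also open, as far as these compounds go, is how other groups on the sulfonyl sulfur, such as 4-methoxyphenyl, 4-aminophenyl or 2-nitrophenyl, would read in this assay, so the part played by the nitro group itself stays undefined.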